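A few compounds are considered here, and "the series" means these few. Any claim that something is new, unique, unknown or untested is made for them only; others in the source may bear on it.

Of the compounds shown here, three have so far been tested in a functional assay on HEp-2 cells (Homo sapiens) for cytotoxicity, read by MTT assay, with a stated time of 72 h; on this read-out higher numbers stand for weaker inhibition and lower numbers for stronger inhibition. Compound 1 `Cc1cc(C)nc(SCc2cc(=O)c3cc(Cl)ccc3o2)n1` reaches only the limit of the assay, giving > 25000 nM. Compound 2 `Cc1nnc(SCc2coc3ccc(Cl)cc3c2=O)o1` gives an actual number, 6400 nM. Compound 3 `Cc1nnc(SCc2cc(=O)c3ccccc3o2)s1`, the starting point here, also stops at the assay limit, with > 25000 nM. Compound 3 therefore stands at the limit of > 25000 nM in this assay, at which 2 of the 3 values shown sit, sharing that position with compound 1, and no more can be said about how strongly it inhibits. Among the measured compounds shown here, no two measured compounds differ in just one place, so no measured step is available to lean on. Compound 4 `Cc1nnc(SCc2cc(=O)c3ccccc3o2)o1` is not yet measured; it keeps the core of compound 3 and differs from it by 5-methyl-1,3,4-oxadiazol-2-yl in place of 5-methyl-1,3,4-thiadiazol-2-yl on a sulfur. For the measured compounds named here, the only measured compound carrying a 5-methyl-1,3,4-oxadiazol-2-yl group is compound 2, with its value of 6400 nM, but it is built on a different core, so its number shows only that such a group can appear in a compound with a measurable value. For the step from compound 3 to compound 4 a change within the usual scatter is expected, leaning if anything toward stronger inhibition, as an at least 1.2-fold lower number from compound 3 to compound 4 (0.09 log units; that floor lies within the scatter). Compound 4 is accordingly estimated at 20000 nM, within a range from 5000 nM to 50000 nM, with a fair chance that only a limit is again reported.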

Compound 4, half-maximal inhibitory concentration: > 25000 nM
Compound 4 ended at the assay's limit; the forecaster's own chance of this, stated with the estimate: 60%; middle value at least 1.2-fold (0.09 log units) from the limit.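

In this assay compound 3 and compound 4 both stop at a limit rather than giving a number, so no step can be read for the change from 5-methyl-1,3,4-thiadiazol-2-yl to 5-methyl-1,3,4-oxadiazol-2-yl: the limit of > 25000 nM in this assay, at which 3 of the 4 values shown sit.

The compounds shown leave open how strongly compound 3 and compound 4 inhibit, and whether this change shifts the value at all on their shared core.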